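The source may hold more compounds than are shown below. What is called first, only, known or untested is meant among the compounds shown, and "the series" means these compounds.

Measured compounds:
- compound 1, `Nc1nc(NC2CC2)c2ncn(/C=C3/CC3(CO)CO)c2n1`: in an ADME assay on Akata cells (Homo sapiens) for cytotoxicity, with a stated time of 7 days (on this read-out higher numbers stand for lower toxicity in this test and lower numbers for higher toxicity in this test), compound 1 gives > 20000 nM, a limit of the assay.
- compound 2, `Nc1nc(NCc2ccccc2)c2ncn(/C=C3/CC3(CO)CO)c2n1`: compound 2 gives > 24000 nM, a limit of the assay.
- compound 3, `CCCCCOc1nc(N)nc2c1ncn2/C=C1/CC1(CO)CO`: compound 3 gives > 20000 nM, a limit of the assay.

Among the compounds with values here, compound 3 stands at a limit in this assay, and the two other values shown are limits as well, so no measured compound sets it apart. The steps among the measured compounds are a step that the two limits leave unreadable from compound 1 to compound 2, a step that the two limits leave unreadable from compound 1 to compound 3 and a step that the two limits leave unreadable from compound 2 to compound 3; each is unreadable, since the values sit at the limit of > 20000 nM in this assay, at which 2 of the 3 values shown sit, and (the limit of > 24000 nM in this assay, at which 1 of the 3 values shown sits). Compound 4, `CCCCNc1nc(N)nc2c1ncn2/C=C1/CC1(CO)CO`, differs from compound 3 as follows: butylamino in place of pentyloxy on an aromatic carbon. Within the data shown here, no measured step bears readably on this change, and every value shown is a limit, so the step that the limit leaves unreadable from compound 3 to compound 4 that he expects is none beyond the scatter. He therefore estimates compound 4 at 30000 nM, with a range from 10000 nM to 100000 nM, most likely again reported only as a limit.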

Compound 4, half-maximal cytotoxic concentration: > 24000 nM
Compound 4 ended at the assay's limit; the forecaster's own chance of this, stated with the estimate: 80%; the middle value lies beyond the limit too.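

In this assay compound 4 gives > 24000 nM, a limit of the assay. Its steps to compound 1, compound 2 and compound 3 cannot be read, as all four values are limits. The compounds shown leave open whether cyclopropylamino, benzylamino, pentyloxy and butylamino differ at all in this assay.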